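Swapping a Fluorinated Ester Group for an Oxetane

A few compounds are considered here, and "the series" means these few. Any claim that something is new, unique, unknown or untested is made for them only; others in the source may bear on it.

Measured so far:
- compound 1, `Cc1nc(S(C)(=O)=O)ccc1Oc1ncnc(OC2CCN(C(=O)OC(C)(C)C(F)(F)F)CC2)c1F`: 79%
- compound 2, `Cc1nc(S(C)(=O)=O)ccc1Oc1ncnc(OC2CCN(C(=O)O[C@H](C)C(F)(F)F)CC2)c1F`: 85%

In a functional assay on isolated protein for inhibition of Glucose-dependent insulinotropic receptor (Rattus norvegicus), read by HTRF and cAMP accumulation (a higher number here means a larger maximal response, a lower number a smaller maximal response), compound 2 gives 85%, the higher of the two numbers, while compound 1 gives 79%; the step of a number 6 percentage points higher from compound 1 to compound 2 (within the scatter) stays within the scatter. Compound 3 `Cc1nc(S(C)(=O)=O)ccc1Oc1ncnc(OC2CCN(C(=O)OC3COC3)CC2)c1F` differs from compound 2 by oxetan-3-yl in place of 1-(trifluoromethyl)ethyl on an oxygen next to a carbonyl group. Among the compounds with values here, the one measured step at this position, a number 6 percentage points higher from compound 1 to compound 2 (within the scatter), is small, so the estimate for compound 3 is a step of about a number 5 percentage points lower from compound 2 to compound 3 (within the scatter), not beyond the scatter. Compound 3 is therefore expected to give 80%, with a range from 60% to 95%.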

Compound 3, largest response reached (reported as efficacy), in percent of the reference or control that the assay uses: 66%
Compound 3: the middle estimate sits 14 percentage points above what was measured; low and high end bracket the measured number.
By their numbers in this assay, from the lowest: compound 3; then compounds 1 and 2 (each within the scatter of the next).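

In this assay, the group on an oxygen next to a carbonyl group proves able to change the maximal response. Exchanging one fluorinated group for the other stayed within the scatter, whereas oxetan-3-yl gives a number 19 percentage points lower from compound 2 to compound 3 (beyond the scatter) and a number 13 percentage points lower from compound 1 to compound 3 (beyond the scatter). No measurement at hand tells what lies behind this difference.

As far as these compounds go, it remains open whether the lower number goes with the four-membered ring, with its oxygen, or with the absence of fluorine. A cyclobutyl group at this position would help separate the ring from its oxygen.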